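Swapping a methylselanyl for an amine on a fused core

A few compounds are considered here, and "the series" means these few. Any claim that something is new, unique, unknown or untested is made for them only; others in the source may bear on it.

Compound 1, with the structure `C[Se]c1nc([Se]C)c2cccnc2n1`, was tested in a functional assay on MCF7 cells (Homo sapiens) for cytotoxicity, read by MTT assay, with a stated time of 72 h (a higher number here means a weaker inhibitor of growth, a lower number a stronger inhibitor of growth), but in that test compound 1 gives "not determined" (no result reported), so no single number came out of it and compound 1 stands nowhere on the scale. The only measured point comes from compound 2, whose structure is `CCCCC[Se]c1nc(NCc2ccc(SC)cc2)c2ccccc2n1`; in this assay compound 2 gives 65000 nM, a weak effect. Compound 3, with the structure `C[Se]c1nc(N)c2cccnc2n1`, has not yet been measured in this assay. Compound 3 differs from compound 1 by one nitrogen atom in place of a group of 2 heavy atoms (1 carbon, 1 selenium; no ring), on an aromatic carbon. Among the measured compounds shown here, no step between two measured compounds of this kind is available, so the size and direction of the change cannot be read from the data; a modest shift in either direction, or none beyond the scatter, is equally plausible, and the single reported value from compound 2 only suggests that this family acts weakly. In this assay compound 3 is expected to give about 50000 nM, with a likely range from 10000 nM to 200000 nM.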

Compound 3, concentration for total growth inhibition: > 100000 nM
Compound 3: only a limit was reported (the forecaster's own chance of this, stated with the estimate: 35%); middle value at least 2.0-fold (0.30 log units) away from the limit.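

Among the compounds shown here, no step from compound 1 to compound 3 can be read, since compound 1 has no reported result. In this assay compound 3 gives > 100000 nM, which is a limit and not a number. The compounds shown leave open whether placing amino on the shared core changes growth inhibition at all, and in which direction.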